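The source may report more compounds than this note shows. Statements on the series, on what has been measured and on what is new or still open speak of the compounds shown alone.

Measured in an ADME assay on BJ cells (Homo sapiens) for cytotoxicity, read by fluorescence, with a stated time of 24 h; on this read-out lower numbers stand for stronger inhibition and higher numbers for weaker inhibition:

Compound 1 `CC(=O)OCCC1S/C(=N\N=C\c2c(-c3ccccc3)[nH]c3ccccc23)NC1=O`: 37100 nM
Compound 2 `O=C1CS/C(=N/N=C/c2c(-c3ccc(Cl)cc3)[nH]c3ccccc23)N1Cc1ccco1`: 8070 nM
Compound 3 `CCC1S/C(=N\N=C\c2c(-c3ccc([N+](=O)[O-])cc3)[nH]c3ccccc23)NC1=O`: 29800 nM

Compound 1 stands level with compound 3, within the scatter, while compound 2 lies lower than compound 1, beyond the scatter. Compound 4 `O=C(CC1S/C(=N\N=C\c2c(-c3ccccc3)[nH]c3ccccc23)NC1=O)c1ccc(F)cc1` has not yet been measured. It keeps the core of compound 1 and differs as follows: (4-fluorophenyl)carbonyl in place of acetoxymethyl on a saturated chain carbon bound to a saturated ring carbon. For the measured compounds named here, no two measured compounds differ in one place only, so the data show no direct precedent for this change. Going by the values given here, a moderate step towards a lower number in this assay is expected, on the loose parallel of compound 2 at 8070 nM, the one measured compound with a further ring. The expected step is a 2.5-fold lower number from compound 1 to compound 4 (0.39 log units; beyond the scatter). For compound 4 the estimated value is 15000 nM, with an expected range of 6000 nM to 35000 nM.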

Compound 4, half-maximal inhibitory concentration: > 50000 nM
Compound 4 ended at the assay's limit; the forecaster's own chance of this, stated with the estimate: 5%; middle value at least 3.3-fold (0.52 log units) away from the limit.
By their numbers in this assay, from the lowest: compound 2; then compounds 3 and 1 (each within the scatter of the next). At a limit, above all of these: compound 4.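

In this assay, (4-fluorophenyl)carbonyl in place of acetoxymethyl on a saturated chain carbon bound to a saturated ring carbon gives an at least 1.3-fold higher number from compound 1 to compound 4 (0.12 log units; that floor lies within the scatter). Compound 4 gives > 50000 nM, which is a limit of the assay and not a number. This position thus carries a further aromatic ring with no lower number appearing, while the true size of the step cannot be read: the limit of > 50000 nM in this assay, at which 1 of the 4 values shown sits.

The compounds shown leave open how an amine, a carboxylic acid or a longer chain at this position would read. As far as these compounds go, whether the fluorine has any part in the result also stays open.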